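Replacing 4-fluorophenyl with pyridin-4-yl: notes on compound 4

The source may report more compounds than this note shows. Statements on the series, on what has been measured and on what is new or still open speak of the compounds shown alone.

In a functional assay on HT-29 cells (Homo sapiens) for inhibition, with a stated time of 72 h (a higher number here means a weaker inhibitor, a lower number a stronger inhibitor), three compounds on a shared core have been measured. Compound 1 `COc1ccc(S(=O)(=O)N2CCc3cccc(-c4ccc(N)cc4)c32)cc1` with an amino group gives 301 nM on this read-out. Compound 2 `COc1ccc(S(=O)(=O)N2CCc3cccc(-c4ccc([N+](=O)[O-])cc4)c32)cc1` with a nitro group gives 51.8 nM and compound 3 `COc1ccc(S(=O)(=O)N2CCc3cccc(-c4ccc(F)cc4)c32)cc1` with a fluoro group gives 85.5 nM as its half-maximal inhibitory concentration. These last two lie within the scatter of each other and both stand clearly under compound 1.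

Compound 4 `COc1ccc(S(=O)(=O)N2CCc3cccc(-c4ccncc4)c32)cc1` carries pyridin-4-yl in place of 4-fluorophenyl on an aromatic carbon. The nearest evidence comes from swaps on that same group: a 5.8-fold lower number from compound 1 to compound 2 (0.76 log units; beyond the scatter) and a 3.5-fold lower number from compound 1 to compound 3 (0.55 log units; beyond the scatter) on leaving the amino group, and a 1.7-fold higher number from compound 2 to compound 3 (0.22 log units; within the scatter) between nitro and fluoro. None of these changes the ring itself, so they suggest only a scale for the step. A modest rise from compound 3 is expected, smaller than a 3.5-fold lower number from compound 1 to compound 3 (0.55 log units; beyond the scatter) in size. The estimated change is a 1.5-fold higher number from compound 3 to compound 4 (0.18 log units; within the scatter) and would remain modest. For compound 4 the expected value is 130 nM with an estimated range from 45 nM to 380 nM at its two ends.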

Compound 4, half-maximal inhibitory concentration: 87.5 nM
For compound 4 the middle estimate is 1.5-fold (0.17 log units) above the measured one; the measured number falls inside the stated range.
By their numbers in this assay, from the lowest: compounds 2, 3 and 4 (each within the scatter of the next); then compound 1.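

In this assay the aromatic ring at this position can itself be exchanged, not only its substituent: pyridin-4-yl in place of 4-fluorophenyl gives a 1.0-fold higher number from compound 3 to compound 4 (0.01 log units; within the scatter), and against the nitro compound the step is a 1.7-fold higher number from compound 2 to compound 4 (0.23 log units; within the scatter). Compound 4 therefore sits with compound 2 and compound 3, although its ring brings a hetero atom and a hydrogen-bond acceptor, while compound 1 stays apart, with a 3.4-fold lower number from compound 1 to compound 4 (0.54 log units; beyond the scatter). Nothing measured here bears on what lies behind these numbers.

Open, from the compounds shown here alone, is whether pyridin-3-yl or pyridin-2-yl, which place the ring nitrogen differently, would read like pyridin-4-yl. Also open, going by these compounds, is how a saturated ring such as piperidine or morpholine, or a carboxylic acid on the phenyl ring, would read at this position.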